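Fluorine on the chain of compound 1

The compounds below may be only part of what the source reports. "The series", "measured", "known", "first", "only" and "open" are said of these compounds alone.

Compound 1 `Cc1cccc(C)c1-c1cccc(COc2ccc(CCC(=O)O)cn2)c1` gives the lowest of the two numbers recorded in a functional assay on CHO cells for agonist activity at Free fatty acid receptor 1 (Homo sapiens), read by calcium flux (on this read-out lower numbers stand for an effect already at smaller amounts and higher numbers for an effect only at larger amounts of compound), namely 3.5 nM. Among the compounds with values here, its one measured neighbour, compound 2 `Cc1cccc(C)c1-c1cccc(COc2ccc(CCC(=O)O)c(C)n2)c1`, gives 81 nM in this assay, and the step between them, a 23-fold higher number from compound 1 to compound 2 (1.36 log units; beyond the scatter), is the only one available; it arises from a methyl in place of hydrogen on an aromatic carbon.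

Compound 3 `Cc1cccc(C)c1-c1cccc(COc2ccc(C(F)CC(=O)O)cn2)c1` has not yet been measured. It differs from compound 1 by fluoro in place of hydrogen on a saturated chain carbon bound to an aromatic carbon and a saturated chain carbon; the change sits on the 2-carboxyethyl chain, which becomes 2-carboxy-1-fluoroethyl.

Within the data shown here, no measured step touches this chain, so the methyl step from compound 1 to compound 2, although large, bears only loosely on the question: it shows that a single added heavy atom on this shared core can shift the read-out strongly, but it sits on a different place. The change in compound 3 introduces no donor, no acceptor and no charge. The expected outcome is therefore a small step, if any, not clearly beyond the scatter, and slightly towards higher numbers, a 1.7-fold higher number from compound 1 to compound 3 (0.23 log units; within the scatter). Compound 3 is thus estimated at 6 nM in this assay, within 1.5 nM to 30 nM.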

Compound 3, half-maximal effective concentration in the Free fatty acid receptor 1 assay: 18 nM
Compound 3: the middle estimate sits 3.0-fold (0.48 log units) below what was measured, within the range that was stated.
By their numbers in the Free fatty acid receptor 1 assay, from the lowest: compound 1; then compound 3; then compound 2.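

In the Free fatty acid receptor 1 assay compound 3 gives 18 nM, and fluoro in place of hydrogen on a saturated chain carbon bound to an aromatic carbon and a saturated chain carbon gives a 5.1-fold higher number from compound 1 to compound 3 (0.71 log units; beyond the scatter), so the 2-carboxyethyl chain, which compound 1 and compound 2 share unchanged, is itself a place where the read-out responds. The earlier compounds shown here showed such a response only for a methyl on an aromatic carbon; here a single fluorine on the chain, entering with no hydrogen-bond donor, no hydrogen-bond acceptor and no net charge, is enough to move the number beyond the scatter. Nothing available here bears on why this change has this effect.

In a physicochemical assay for lipophilicity, at pH 7.4 (on this read-out higher numbers stand for higher lipophilicity and lower numbers for lower lipophilicity), compound 1 gives 3, but compound 3 stands as "not determined" (no result reported), so the step between them cannot be read. From the compounds shown here alone, it also remains open how the same chain carbon would respond to a hydroxyl group, a methyl group or a second fluorine, and whether the fluoro step would keep its size on a longer chain.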